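A few compounds are considered here, and "the series" means these few. Any claim that something is new, unique, unknown or untested is made for them only; others in the source may bear on it.

Compound 1 `COc1ccc(/C=C/c2cc(OC)cc(OC)c2/C=C/C(=O)c2ccc(N)cc2)cc1` is measured in a functional assay on A549 cells (Homo sapiens) for antiproliferative activity, read by MTT assay, with a stated time of 48 h (on this read-out higher numbers stand for weaker inhibition and lower numbers for stronger inhibition), where compound 1 gives 3.8 ug/mL, the lowest of the three numbers shown, though its gaps to the other two stay within the scatter. Compound 2 `CCOc1ccc(C(=O)/C=C/c2c(/C=C/c3ccc(OC)cc3)cc(OC)cc2OC)cc1` gives 7.5 ug/mL in this assay, and compound 3 `COc1ccc(/C=C/c2cc(OC)cc(OC)c2/C=C/C(=O)c2ccc(Cl)cc2)cc1` gives 6.4 ug/mL. Compound 4 `COc1ccc(/C=C/c2cc(OC)cc(OC)c2/C=C/C(=O)c2ccc(-c3ccccc3)cc2)cc1` is not yet measured; relative to compound 1 it carries phenyl in place of amino on an aromatic carbon. Two measured steps change the same position and bear on it: a 2.0-fold higher number from compound 1 to compound 2 (0.30 log units; within the scatter) and a 1.7-fold higher number from compound 1 to compound 3 (0.23 log units; within the scatter), both within the scatter. Neither speaks directly to a phenyl group, so nothing beyond the scatter is expected in this assay, with perhaps a slight drift toward higher numbers. Compound 4 is therefore expected to give 6 ug/mL, between 2.5 ug/mL and 14 ug/mL, a step expected as a 1.6-fold higher number from compound 1 to compound 4 (0.20 log units; within the scatter).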

Compound 4, half-maximal inhibitory concentration: 4.6 ug/mL
The estimate for compound 4 lay 1.3-fold (0.12 log units) above the measured number; low and high end bracket the measured number.
By their numbers in this assay, from the lowest: compounds 1, 4, 3 and 2 (each within the scatter of the next).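

In this assay, phenyl brings a ring to this position and removes the hydrogen-bond donor of amino, yet the step stays within the scatter: a 1.2-fold higher number from compound 1 to compound 4 (0.08 log units; within the scatter). The steps from the other two groups also stay within the scatter: a 1.4-fold lower number from compound 3 to compound 4 (0.14 log units; within the scatter) and a 1.6-fold lower number from compound 2 to compound 4 (0.21 log units; within the scatter). Thus four different groups at this position, including one carrying a whole ring, give numbers that cannot be told apart, and no evidence here explains this.

From the compounds shown here alone, whether any group at this position can move the number beyond the scatter remains open. A carboxylic acid or a dimethylamino group there is untested among the compounds shown.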